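Dichloroacetanilides: halogen exchange on the ring

This account rests on a few compounds, and the source may have more. Where it says the series, first, only, none or still open, it means among the compounds named here.

Compound 1 `O=C(Nc1cccc(Br)c1)C(Cl)Cl` gives 8180 nM in a functional assay on KB cells (Homo sapiens) for antiproliferative activity, read by MTT assay, with a stated time of 72 h; a lower number here means a stronger inhibitor, a higher number a weaker inhibitor. Compound 2 `O=C(Nc1cccc(I)c1)C(Cl)Cl` carries the change iodo in place of bromo on an aromatic carbon and gives 5250 nM in this assay; the step is a 1.6-fold lower number from compound 1 to compound 2 (0.19 log units; within the scatter). Compound 3 `O=C(Nc1ccc(Br)cc1)C(Cl)Cl` has the same atoms as compound 1, joined differently, and the difference between the two cores is not broken down here; in this assay compound 3 gives 21700 nM, the highest number of the three measured. Compound 4 `O=C(Nc1ccc(I)cc1)C(Cl)Cl` has not yet been measured. It differs from compound 3 by iodo in place of bromo on an aromatic carbon, the same kind of change as from compound 1 to compound 2, but here para rather than meta to a group of 6 heavy atoms. Within the data shown here, on the single measured pair, a 1.6-fold lower number from compound 1 to compound 2 (0.19 log units; within the scatter), a step of a 1.6-fold lower number from compound 3 to compound 4 (0.19 log units; within the scatter) is expected from compound 3 to compound 4 in this assay. Compound 4 is estimated at 14000 nM, between 6000 nM and 32000 nM.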

Compound 4, half-maximal inhibitory concentration: 66200 nM
Beside the measured number, compound 4's estimate is 4.7-fold (0.67 log units) below it; measured number outside the range, above it.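

Iodo in place of bromo does not carry over unchanged between these two cores in this assay: the same change on two cores in this assay, a 1.6-fold lower number (0.19 log units; within the scatter) from compound 1 to compound 2 and a 3.1-fold higher number (0.48 log units; beyond the scatter) from compound 3 to compound 4, 4.8-fold (0.68 log units) apart, beyond the scatter of two such steps. On the core of compound 3, the exchange gives a 3.1-fold higher number from compound 3 to compound 4 (0.48 log units; beyond the scatter), so the step read on the core of compound 1 gives no reliable estimate for this core. Among these compounds, with only one pair on each core, this shows that the outcome of the exchange differs between these two cores, but not what in the cores sets that difference or how the exchange would behave on a further core.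

As far as these compounds go, whether chloro or fluoro on the ring would follow either core remains open. So does the outcome of putting an amine or a carboxylic acid in place of the halogen.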